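The compounds below may be only part of what the source reports. "The series", "measured", "known", "first", "only" and "open" are said of these compounds alone.

In an ADME assay on Huh7.5.1 cells (Homo sapiens) for cytotoxicity, read by WST assay, with a stated time of 48 h (a higher number here means that more compound is tolerated, a lower number that less compound is tolerated), compound 3 `Cc1c(-c2ccc(Oc3ccc(SC(F)(F)F)cc3)c(F)c2)[nH]c2cccc(F)c2c1=O` gives > 10000 nM, which is a limit of the assay and not a number. For the measured compounds named here, two relatives offer the only comparison. Compound 1 `Cc1c(-c2ccc(Cc3ccc([S+]([O-])C(F)(F)F)cc3)cc2)[nH]c2cccc(F)c2c1=O` gives > 5000 nM, also a limit. Compound 2 `Cc1c(-c2ccc(Cc3ccc(OC(F)F)cc3)cc2)[nH]c2cccc(F)c2c1=O` gives > 5000 nM, again a limit. None of the three has yet given a true number.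

Compound 4 `CCNc1ccc(Oc2ccc(-c3[nH]c4cccc(F)c4c(=O)c3C)cc2F)cc1` carries ethylamino in place of the (trifluoromethyl)sulfanyl of compound 3 (ethylamino in place of (trifluoromethyl)sulfanyl on an aromatic carbon), on an aromatic carbon para to a large group. Going by the values given here, the one measured step that bears on this is a step that the two limits leave unreadable from compound 1 to compound 2, which also exchanges a group on an aromatic carbon but has no readable size to carry over.

The expectation therefore leans on compound 3, whose > 10000 nM is a limit. With no measured size to go on, no shift beyond the scatter is expected in either direction, and the expected result is a number no higher from compound 3 to compound 4 (the limit leaves the size open). For compound 4 the estimate is 10000 nM, with an expected range from 3500 nM to 25000 nM.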

Compound 4, half-maximal cytotoxic concentration: > 10000 nM
Compound 4: only a limit was reported (the forecaster's own chance of this, stated with the estimate: 65%); the middle value lies on the limit itself.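

Compound 3 and compound 4 each give only a limit of the assay, not a number, and the step between them cannot be read. The compounds shown leave open what concentration of any of them harms these cells, and whether ethylamino in place of (trifluoromethyl)sulfanyl changes it.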